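Chloro gives way to methoxy on an aromatic carbon

A few compounds are considered here, and "the series" means these few. Any claim that something is new, unique, unknown or untested is made for them only; others in the source may bear on it.

Three compounds sharing one core have been measured in a physicochemical assay for lipophilicity (a higher number here means a more lipophilic compound, a lower number a more polar compound), so far:
- compound 1 `C[C@H]1CC[C@@H]2[C@@H](OC(=O)[C@]23CC(c2ccc(Br)cc2)N(c2ccccc2)O3)[C@]2(C)C(=O)C=C[C@@]12O` at 4
- compound 2 `C[C@H]1CC[C@@H]2[C@@H](OC(=O)[C@]23CC(c2c(Cl)cccc2Cl)N(c2ccccc2)O3)[C@]2(C)C(=O)C=C[C@@]12O` at 4.45
- compound 3 `C[C@H]1CC[C@@H]2[C@@H](OC(=O)[C@]23CC(c2cccc(Cl)c2)N(c2ccccc2)O3)[C@]2(C)C(=O)C=C[C@@]12O` at 3.87

Compound 3 is the starting point. On one side its gap is too small to count (a number 0.13 log units lower from compound 1 to compound 3 (within the scatter)), and on the other it is real (a number 0.58 log units lower from compound 2 to compound 3 (beyond the scatter)).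

The next structure, compound 4 `COc1cccc(C2C[C@@]3(ON2c2ccccc2)C(=O)O[C@@H]2[C@H]3CC[C@H](C)[C@]3(O)C=CC(=O)[C@@]23C)c1`, alters a single group: methoxy in place of chloro on an aromatic carbon, meta to a large group (methoxy in place of chloro on an aromatic carbon). The group that enters counts a hydrogen-bond acceptor, and the one that leaves counts none.

Among the compounds with values here, no measured step makes this exact exchange, so the nearest evidence is indirect. Replacing one aryl group with another has so far produced nothing beyond a modest step (a number 0.45 log units higher from compound 1 to compound 2 (beyond the scatter)). The step from 2,6-dichlorophenyl to 3-chlorophenyl went down (a number 0.58 log units lower from compound 2 to compound 3 (beyond the scatter)), and the coming change also gives up a chlorine. All three measured compounds carry halogen on this ring, so the direction remains a tentative call. A modest downward step is therefore expected (a number 0.42 log units lower from compound 3 to compound 4 (beyond the scatter)). The estimated value for compound 4 is 3.45 (range 3.05 to 3.85).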

Compound 4, partition coefficient: 3.25
Compound 4: the middle estimate sits 0.20 log units above what was measured, and the stated range covers the measured number.
By their numbers in this assay, from the lowest: compound 4; then compounds 3 and 1 (each within the scatter of the next); then compound 2.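

In this assay, within the data shown here, the exchange of chloro for methoxy on an aromatic carbon, meta to a large group, gives the first direct reading of a group without halogen on this ring, and the number falls by a modest but real amount (a number 0.62 log units lower from compound 3 to compound 4 (beyond the scatter)). Read as whole-ring swaps, 3-methoxyphenyl also stands clearly apart from the two halogen-bearing rings, by a modest step from one (a number 0.75 log units lower from compound 1 to compound 4 (beyond the scatter)) and by the only large step in the series so far from the other (a number 1.20 log units lower from compound 2 to compound 4 (beyond the scatter)). The entering methoxy counts a hydrogen-bond acceptor and the leaving chloro counts none, but no other measurement here links that difference to the drop.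

Among these compounds, with compound 4 as the single methoxy example, one exchange at one place cannot show whether methoxy elsewhere on this ring would give a step of similar size. Going by these compounds, how a hydroxyl, an amine or a carboxylic acid at this same place would compare with methoxy also remains open, as does whether any of them would take the number lower still.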